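Ethyl for methyl on the lactam nitrogen in a pyrimidine series

The compounds below may be only part of what the source reports. "The series", "measured", "known", "first", "only" and "open" are said of these compounds alone.

Measured compounds:
- compound 1, `CN1C(=O)CN(C2CCCC2)c2nc(Nc3ccc(N4CCCCC4)cc3)ncc21`: 25300 nM
- compound 2, `CN1CCN(c2ccc(Nc3ncc4c(n3)N(C3CCCC3)CC(=O)N4C)nc2)CC1`: "not determined" (no result reported)
- compound 3, `CCN1C(=O)CN(C2CCCC2)c2nc(Nc3ccc(N4CCCCC4)cc3)ncc21`: > 30000 nM

In an ADME assay on HEK293 cells (Homo sapiens) for inhibition, read by MTT assay, with a stated time of 48 h (on this read-out higher numbers stand for weaker inhibition and lower numbers for stronger inhibition), compound 1 gives 25300 nM. Compound 3 reaches only a limit of the assay in this assay, > 30000 nM, and (the limit of > 30000 nM in this assay, at which 1 of the 3 values shown sits). Compound 2 has no result reported in this assay. The change from compound 1 to compound 3 is methyl in place of hydrogen on a saturated chain carbon bound to an amide-type nitrogen in a ring, and it made an at least 1.1-fold higher number from compound 1 to compound 3 (0.07 log units; that floor lies within the scatter).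

Compound 4, `CCN1C(=O)CN(C2CCCC2)c2nc(Nc3ccc(N4CCN(C)CC4)cn3)ncc21`, is not yet measured. Among the measured compounds shown here, it differs from compound 2 by methyl in place of hydrogen on a saturated chain carbon bound to an amide-type nitrogen in a ring, which is the same change as the one from compound 1 to compound 3. The difference between the two cores, that of compound 1 and that of compound 2, is not broken down here.

What to expect of compound 4 in this assay rests on thin ground. For the measured compounds named here, compound 2 has no number, so the step from compound 2 to compound 4 cannot be placed beside the earlier one, and the only guide is that compound 1 sits at 25300 nM. For compound 3 the same change gave a limit of the assay. On that basis compound 4 is expected to give about 30000 nM in this assay, with a plausible range from 10000 nM to 90000 nM, and a real chance that only a limit is reported.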

Compound 4, half-maximal inhibitory concentration: > 30000 nM
Compound 4: no number, only a limit; the forecaster's own chance of this, stated with the estimate: 55%; the middle value sits exactly at the limit.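

In this assay compound 4 gives > 30000 nM, which is a limit of the assay and not a number. Among the compounds shown here, compound 2 has no number to set against it, so no step from compound 2 to compound 4 can be read. The compounds shown leave open whether methyl in place of hydrogen at this place changes the read-out at all on the core of compound 2.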